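A few compounds are considered here, and "the series" means these few. Any claim that something is new, unique, unknown or untested is made for them only; others in the source may bear on it.

Measured in a functional assay on HCT-116 cells (Homo sapiens) for antiproliferative activity, read by MTT assay, with a stated time of 48 h; a higher number here means a weaker inhibitor, a lower number a stronger inhibitor:
- compound 1 `CC(CCO)n1cnc2c(Cl)nc(F)nc21`: 19800 nM
- compound 2 `CCCCCCCCC(CCO)n1cnc2c(Cl)nc(F)nc21`: 24200 nM
- compound 3 `CCCCCCCCCC(CCO)n1cnc2c(Cl)nc(F)nc21`: not yet measured

Compound 2, at 24200 nM, stands within the scatter of compound 1, at 19800 nM, so the two cannot be ranked on these numbers. The next structural change is methyl in place of hydrogen on a saturated chain carbon, nine bonds along the chain from an aromatic nitrogen.

Among the measured compounds shown here, only one measured step bears on this change: a 1.2-fold higher number from compound 1 to compound 2 (0.09 log units; within the scatter). That step is heptyl in place of hydrogen on a saturated chain carbon, two bonds along the chain from an aromatic nitrogen. It adds far more to the structure than a single methyl and still stays within the scatter. For the measured compounds named here, one step is thin evidence, and no measured pair tests a change at the far end of the chain. Even so, no step beyond the scatter is expected in this assay, and no direction can be called. The estimated step is a 1.0-fold lower number from compound 2 to compound 3 (0.00 log units; within the scatter). The expected value for compound 3 is 24000 nM, with an estimated range of 12000 nM to 50000 nM.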

Compound 3, half-maximal inhibitory concentration: 32100 nM
The estimate for compound 3 lay 1.3-fold (0.13 log units) below the measured number; the measured number falls inside the stated range.
By their numbers in this assay, from the lowest: compounds 1, 2 and 3 (each within the scatter of the next).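

In this assay, among the compounds shown here, the result gives the first direct reading at this far position of the chain: methyl in place of hydrogen on a saturated chain carbon, nine bonds along the chain from an aromatic nitrogen, gives a 1.3-fold higher number from compound 2 to compound 3 (0.12 log units; within the scatter) for this one added carbon. Read across the whole chain difference, the change in the chain gives a 1.6-fold higher number from compound 1 to compound 3 (0.21 log units; within the scatter) and still does not separate the two compounds, so neither the small change nor the large one shows a measurable preference in this assay among the compounds shown. No accompanying measurement bears on this result.

On these data alone, whether a longer chain such as dodecyl, or an amine or a carboxylic acid in place of hydrogen at the same chain carbon, would give a step beyond the scatter remains open. The three compounds also share the hydroxyl group and the core, so these chain steps say nothing about changes at either of those places.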